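Carboxyphenyl ether variants of the shared core

A few compounds are considered here, and "the series" means these few. Any claim that something is new, unique, unknown or untested is made for them only; others in the source may bear on it.

Among the compounds with values here, compound 2 `Cc1c(OCCCCOc2cccc(C(=O)O)c2)ccc(C(=O)CC(C)C)c1O` gives 222 nM in an assay on HEK293 cells for positive allosteric modulation of metabotropic glutamate receptor 2 (Rattus norvegicus), read by thallium flux, with a stated time of 2.5 min (a lower number here means that less compound is needed, a higher number that more compound is needed for the effect), the highest of the two numbers so far; its nearest neighbour is compound 1 `Cc1c(OCCCCOc2ccc(C(=O)O)cc2Cl)ccc(C(=O)CC(C)C)c1O`, which in this assay gives 96 nM, the step being a 2.3-fold higher number from compound 1 to compound 2 (0.36 log units; beyond the scatter). Compound 3 `Cc1cc(OCCCCOc2ccc(C(=O)CC(C)C)c(O)c2C)ccc1C(=O)O` differs from compound 2 by 4-carboxy-3-methylphenyl in place of 3-carboxyphenyl on an oxygen on a saturated carbon. Within the data shown here, only that one step bears on this change, and the carboxy group of compound 3 is placed as in the 4-carboxy-2-chlorophenyl of compound 1 rather than as in the 3-carboxyphenyl of compound 2, so a modest lower number, a 1.9-fold lower number from compound 2 to compound 3 (0.27 log units; within the scatter), is expected. Compound 3 is estimated at 120 nM, range 40 nM to 360 nM.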

Compound 3, half-maximal effective concentration: 173 nM
Estimate against measurement, compound 3: 1.4-fold (0.16 log units) below; the measured number falls inside the stated range.
By their numbers in this assay, from the lowest: compounds 1, 3 and 2 (each within the scatter of the next, the first and the last beyond it).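

In this assay, 4-carboxy-3-methylphenyl in place of 3-carboxyphenyl gives a 1.3-fold lower number from compound 2 to compound 3 (0.11 log units; within the scatter) and in place of 4-carboxy-2-chlorophenyl gives a 1.8-fold higher number from compound 1 to compound 3 (0.26 log units; within the scatter). Compound 3 therefore lies within the scatter of both compound 1 and compound 2, although those two differ beyond it, so this position tolerates the change without a resolved shift in either direction. Nothing available explains these small steps.

Still open, on these data alone, is how the unsubstituted 4-carboxyphenyl group would compare on the same oxygen, which would separate the placement of the carboxy group from the chloro and methyl groups. Also open, as far as these compounds go, is whether a tetrazole can stand in for the carboxylic acid.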